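The compounds below may be only part of what the source reports. "The series", "measured", "known", "first", "only" and "open" are said of these compounds alone.

Two compounds built on a shared core have been characterised in an assay on CHO cells for displacement of a labelled ligand from adenosine receptor A1 (Homo sapiens), read by scintillation counting, tested at 10 uM; a higher number here means more inhibition at the concentration tested (going by the name of the read-out), a lower number less inhibition. Compound 1, with the structure `Nc1sc(-c2ccccc2)c(-c2ccccc2)c1C(=O)c1ccc(Cl)cc1`, gives 1% in this assay. Compound 2, with the structure `CC(C)(C)Cc1c(-c2c(F)cccc2F)sc(N)c1C(=O)c1ccc(Cl)cc1`, gives 1% in this assay. Compound 2 thus stands level with compound 1 at the digits shown; nothing beyond the usual scatter separates the two, and no order between them can be read from these numbers. Compound 3, with the structure `CC(C)(C)Cc1c(Br)sc(N)c1C(=O)c1ccc(Cl)cc1`, has not yet been measured in this assay. It differs from compound 2 in a single place: bromo in place of 2,6-difluorophenyl on an aromatic carbon. Within the data shown here, no pair of measured compounds differing in one place exists here, so there is no measured step to lean on, and the two measured values both lie near the floor of the scale. On that footing the step of a number 1 percentage points higher from compound 2 to compound 3 (within the scatter) is expected to be none beyond the scatter. Compound 3 is therefore estimated to give 2% in this assay, with a range from -8% to 14%.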

Compound 3, a percentage reported as inhibition, at one concentration (the size of the read-out at that concentration, not a potency): 1%
Beside the measured number, compound 3's estimate is 1 percentage points above it, within the range that was stated.
By their numbers in this assay, from the lowest: compounds 1, 2 and 3 (each within the scatter of the next).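

In this assay, among these compounds, putting bromo in place of 2,6-difluorophenyl on the aromatic carbon next to the ring sulfur brings no change at the digits printed from compound 2 to compound 3 (within the scatter), the first measured step at this position. The change is a large one in structure, since a group of eight heavy atoms with its six-membered aromatic ring gives way to a single bromine, and even so the read-out stays near the floor of the scale. At this level, the step shows that neither group gives a measurable inhibition with the neopentyl and (4-chlorophenyl)carbonyl groups in place, but it cannot rank the two groups, and nothing at hand offers an explanation for the result.

The compounds shown leave open whether any other group on this carbon, such as a carboxylic acid, a piperidine ring or a longer alkyl chain, would raise the inhibition above the scatter. They also leave open whether a replacement for the neopentyl group, such as a methyl or a benzyl group, would make a change at the bromo position readable at all.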